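Chloro to bromo exchange in a small cytotoxicity series

This account rests on a few compounds, and the source may have more. Where it says the series, first, only, none or still open, it means among the compounds named here.

Measured compounds in a functional assay on NCI-H460 cells (Homo sapiens) for cytotoxicity, read by sulforhodamine B assay, with a stated time of 3 days; on this read-out higher numbers stand for weaker inhibition and lower numbers for stronger inhibition:
compound 1, `OCc1cn(Cc2cccc(Cl)c2)c2ccccc12`: 19 nM
compound 2, `OCc1cn(Cc2ccc(Cl)cc2)c2ccccc12`: 16 nM
compound 3, `OCc1cn(Cc2cccc(Br)c2)c2ccccc12`: 28 nM

The three measured compounds share one core and differ only in a halogen on the benzyl ring and in where that halogen sits. Compound 1 and compound 2 have the same atoms joined differently; the difference between the two cores is not broken down here. From compound 1 to compound 3 the change is bromo in place of chloro on an aromatic carbon, and this gave a 1.5-fold higher number from compound 1 to compound 3 (0.17 log units; within the scatter). The values of compound 2 and compound 1 lie within the scatter of each other, as do those of compound 2 and compound 3.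

Compound 4, `OCc1cn(Cc2ccc(Br)cc2)c2ccccc12`, is not yet measured. It arises from compound 2 by bromo in place of chloro on an aromatic carbon. This is the same kind of change as that from compound 1 to compound 3, not the same: there the place is meta to a large group, here it is para to a large group. Because the earlier step was a 1.5-fold higher number from compound 1 to compound 3 (0.17 log units; within the scatter), a step of similar size is expected, namely a 1.5-fold higher number from compound 2 to compound 4 (0.18 log units; within the scatter), starting from compound 2 at 16 nM. Compound 4 is therefore estimated at 24 nM, expected between 12 nM and 50 nM in this assay.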

Compound 4, half-maximal inhibitory concentration: 31 nM
For compound 4 the middle estimate is 1.3-fold (0.11 log units) below the measured one; low and high end bracket the measured number.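

In this assay, bromo in place of chloro on an aromatic carbon, para to a large group, gave a 1.9-fold higher number from compound 2 to compound 4 (0.29 log units; within the scatter), and this step can be set beside the earlier case of the same exchange. The two steps agree within the scatter: the same change on two cores in this assay, a 1.5-fold higher number (0.17 log units; within the scatter) from compound 1 to compound 3 and a 1.9-fold higher number (0.29 log units; within the scatter) from compound 2 to compound 4, 1.3-fold (0.12 log units) apart, within the scatter of two such steps. The exchange therefore carries from the core of compound 1 to the core of compound 2 without any detectable difference in the size of the step, but each step lies within the scatter on its own, so the pairs do not show that bromo and chloro differ in this assay, and two pairs say nothing about other cores.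

The compounds shown carry only chloro and bromo on the benzyl ring, which leaves open whether fluoro, methoxy or a nitrile there would give similar numbers. From the compounds shown here alone, the hydroxymethyl group is the same throughout, so it also remains open how an amine or a carboxylic acid in its place would read.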